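The source may report more compounds than this note shows. Statements on the series, on what has been measured and on what is new or still open speak of the compounds shown alone.

Compound 1 `COc1ccccc1C(=O)NC(CC(=O)O)c1ccc(C(C)(C)C)cc1` and compound 2 `CC(C)(C)c1ccc(C(CC(=O)O)NC(=O)c2c(Cl)cccc2Cl)cc1` share a core that carries a benzamide-type group, and the two differ only in that group: 2,6-dichlorophenyl in place of 2-methoxyphenyl on a carbonyl carbon. In a functional assay on MDA-MB-231 cells (Homo sapiens) for antiproliferative activity, read by MTT assay, with a stated time of 24 h (on this read-out lower numbers stand for stronger inhibition and higher numbers for weaker inhibition), compound 1 gives only a limit, > 100000 nM, and no number. In this assay compound 2 likewise gives only a limit, > 100000 nM. The step that the two limits leave unreadable from compound 1 to compound 2 therefore cannot be read in size, since both ends rest on the limit described by the limit of > 100000 nM in this assay, at which 3 of the 3 values shown sit.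

Compound 3 `COc1ccccc1C(=O)NC(CC(=O)O)c1ccc(Cl)cc1Cl` carries the 2-methoxyphenyl group of compound 1 on a different core; how the core of compound 3 differs from the core of compound 1 is not broken down here. In this assay compound 3 again gives only a limit, > 100000 nM.

Compound 4 `O=C(O)CC(NC(=O)c1c(Cl)cccc1Cl)c1ccc(Cl)cc1Cl` is not yet measured. It differs from compound 3 in the same way that compound 2 differs from compound 1: 2,6-dichlorophenyl in place of 2-methoxyphenyl on a carbonyl carbon. Both changes sit on a carbonyl carbon whose other neighbour is an amide-type nitrogen, so the change is of the same kind.

Since every value shown so far sits at the limit given by the limit of > 100000 nM in this assay, at which 3 of the 3 values shown sit, and since the earlier step that the two limits leave unreadable from compound 1 to compound 2 gave no readable size, the expected step that the limit leaves unreadable from compound 3 to compound 4 is, by estimate, also too small to lift compound 4 off that limit. Compound 4 is thus expected to come in at about 200000 nM, between 50000 nM and 1000000 nM, with a high chance that only a limit is reported.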

Compound 4, half-maximal inhibitory concentration: > 100000 nM
Compound 4: no number, only a limit; the forecaster's own chance of this, stated with the estimate: 85%; the middle value lies beyond the limit too.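

No new step can be read from this result: in this assay compound 3 and compound 4 both give only a limit and no number, so the size of the change between them stays unknown: the limit of > 100000 nM in this assay, at which 4 of the 4 values shown sit.

The compounds shown leave open how far any of them lies beyond that limit, and whether 2,6-dichlorophenyl in place of 2-methoxyphenyl changes the read-out at all.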